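Chain length and branching at the ketone-linked acid group

The source may report more compounds than this note shows. Statements on the series, on what has been measured and on what is new or still open speak of the compounds shown alone.

Measured compounds:
compound 1 `CCCc1c(COc2ccc(C(=O)Cc3nnn[nH]3)cc2)ccc(C(C)=O)c1O` gives 24.1 mg/kg in an in vivo functional assay on the whole organism (Rattus norvegicus) with cysteinyl leukotriene receptor (Homo sapiens) as the target; on this read-out lower numbers stand for an effect already at smaller amounts and higher numbers for an effect only at larger amounts of compound
compound 2 `CCCc1c(COc2ccc(C(=O)CCC(=O)O)cc2)ccc(C(C)=O)c1O` gives 18.2 mg/kg in this assay
compound 3 `CCCc1c(COc2ccc(C(=O)C(C)(C)Cc3nnn[nH]3)cc2)ccc(C(C)=O)c1O` gives 10.8 mg/kg in this assay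

Compound 3 stands at the lowest number of the three in this assay. Compound 2 is the nearest, a 1.7-fold lower number from compound 2 to compound 3 (0.23 log units; within the scatter), so the two are not separated; compound 1 is the furthest, a 2.2-fold lower number from compound 1 to compound 3 (0.35 log units; beyond the scatter). Between compound 1 and compound 2 the change of the acid group gives a 1.3-fold lower number from compound 1 to compound 2 (0.12 log units; within the scatter).

Compound 4 `CCCc1c(COc2ccc(C(=O)CCCc3nnn[nH]3)cc2)ccc(C(C)=O)c1O` has not been measured. It differs from compound 3 in one place: 3-(1H-tetrazol-5-yl)propyl in place of 1-((1H-tetrazol-5-yl)methyl)-1-methylethyl on a carbonyl carbon. Two aspects of this change can be weighed. The branching that distinguishes compound 3 from compound 1 is removed, and the step from compound 1 to compound 3, a 2.2-fold lower number from compound 1 to compound 3 (0.35 log units; beyond the scatter), was the only one beyond the scatter, so its removal would be expected to move the number back toward that of compound 1. Among the compounds with values here, at the same time the chain to the tetrazole is lengthened, for which no directly comparable step exists; the nearest reference, the step from compound 1 to compound 2, lay within the scatter. On balance a modest rise in the number is expected, a 1.7-fold higher number from compound 3 to compound 4 (0.22 log units; within the scatter), with a good chance that it remains within the scatter of compound 3. For compound 4 the expected value in this assay is 18 mg/kg, with a range from 8 mg/kg to 40 mg/kg.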

Compound 4, dose for half-maximal effect: 7.2 mg/kg
Compound 4: middle estimate off by 2.5-fold (0.40 log units), on the high side; measured number outside the range, below it.
By their numbers in this assay, from the lowest: compounds 4, 3, 2 and 1 (each within the scatter of the next, the first and the last beyond it).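

The unbranched 3-(1H-tetrazol-5-yl)propyl on the carbonyl carbon is not separated from the branched 1-((1H-tetrazol-5-yl)methyl)-1-methylethyl, with a 1.5-fold lower number from compound 3 to compound 4 (0.18 log units; within the scatter), so in this assay the branching is not required to reach the low end of the series. Chain length alone now gives a step beyond the scatter, a 3.3-fold lower number from compound 1 to compound 4 (0.52 log units; beyond the scatter), where 2-(1H-tetrazol-5-yl)ethyl replaces 1H-tetrazol-5-yl on a saturated chain carbon bound to a carbonyl carbon, and a tetrazole-bearing chain also separates from the carboxylic acid, with a 2.5-fold lower number from compound 2 to compound 4 (0.40 log units; beyond the scatter), which the shorter tetrazole chain did not do in a 1.3-fold lower number from compound 1 to compound 2 (0.12 log units; within the scatter). No available evidence bears on the origin of these steps.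

From the compounds shown here alone, whether the trend continues with a longer chain, such as 4-(1H-tetrazol-5-yl)butyl, remains open, since only the shorter chain lengths are covered here. Also open, going by these compounds, is how 3-carboxypropyl, a carboxylic acid on a longer chain, would compare with the 3-(1H-tetrazol-5-yl)propyl of compound 4, which would separate the effect of the acid group from that of chain length.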